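Removing the chloro from compound 3: an expectation

The compounds below may be only part of what the source reports. "The series", "measured", "known", "first", "only" and "open" are said of these compounds alone.

Measured compounds:
- compound 1, `CCCN(CCC)c1cc(C)nc2c(-c3ncc(N)cc3C)c(C)nn12`, gives 85 nM
- compound 2, `CCCN(CCC)c1cc(C)nc2c(-c3ncc(NC)cc3C)c(C)nn12`, gives 40 nM
- compound 3, `CCCN(CCC)c1cc(C)nc2c(-c3ncc(Cl)cc3C)c(C)nn12`, gives 6.7 nM

All three share one core and differ only in the group on the pyridine ring. In an assay on isolated protein for binding affinity to corticotropin-releasing factor receptor 1 (Homo sapiens) (a higher number here means a weaker inhibitor, a lower number a stronger inhibitor), compound 3 stands lowest of the three, with a 6.0-fold lower number from compound 2 to compound 3 (0.78 log units; beyond the scatter) and a 13-fold lower number from compound 1 to compound 3 (1.10 log units; beyond the scatter), both steps beyond the scatter.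

Compound 4, `CCCN(CCC)c1cc(C)nc2c(-c3ncccc3C)c(C)nn12`, has not been measured. It differs from compound 3 by hydrogen in place of chloro on an aromatic carbon; the same difference, cut one bond further out, reads 5-chloro-3-methylpyridin-2-yl to 3-methylpyridin-2-yl.

For the measured compounds named here, no measured step swaps chloro for hydrogen at this carbon. Going by the values given here, the steps that bear on it are the two that change the chloro into something else: a 13-fold lower number from compound 1 to compound 3 (1.10 log units; beyond the scatter) and a 6.0-fold lower number from compound 2 to compound 3 (0.78 log units; beyond the scatter). Both say that taking the chloro away, in the directions tried so far, raised the number clearly. Taken together they suggest that compound 4, with only hydrogen at that place, is expected to give a higher number than compound 3, estimated as a 3.7-fold higher number from compound 3 to compound 4 (0.57 log units; beyond the scatter).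

For compound 4 the estimate in this assay is 25 nM, with a range from 8 nM to 80 nM.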

Compound 4, inhibition constant: 110 nM
For compound 4 the middle estimate is 4.4-fold (0.64 log units) below the measured one; measured number outside the range, above it.
By their numbers in this assay, from the lowest: compound 3; then compound 2; then compounds 1 and 4 (each within the scatter of the next).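

Compound 4 gives this carbon its first baseline with hydrogen alone, and in this assay the change from chloro to hydrogen gives a 16-fold higher number from compound 3 to compound 4 (1.22 log units; beyond the scatter), so the chloro itself brings a large gain over an unsubstituted carbon. The earlier compounds shown here could not show this, since they compared the chloro only with amino and methylamino, leaving open whether the chloro helped or those two groups did harm. The baseline also separates those two groups: amino cannot be told apart from hydrogen, with a 1.3-fold higher number from compound 1 to compound 4 (0.11 log units; within the scatter), while the methylamino of compound 2 keeps a modest edge over hydrogen, as a 2.8-fold higher number from compound 2 to compound 4 (0.44 log units; beyond the scatter) shows, so neither group is a penalty compared with hydrogen.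

The compounds shown leave open whether the gain belongs to chloro alone or would also appear with fluoro, bromo, methyl or methoxy on this carbon, and whether a larger amine could extend the edge seen with methylamino. No measurement here explains why the chloro has this effect.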